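Stretching the nitrogen chain from butyl to octyl

The compounds below may be only part of what the source reports. "The series", "measured", "known", "first", "only" and "open" are said of these compounds alone.

Compound 1 `COCCOc1c2ccccc2nn1C(C)C` gives 1400 nM in an assay on isolated protein (urine) for inhibition of Myeloperoxidase (Homo sapiens), read by spectrophotometry; a lower number here means a stronger inhibitor, a higher number a weaker inhibitor.
Compound 2 `CCCCn1nc2ccccc2c1OC` gives 910 nM in this assay.
Compound 3 `CCCCn1nc2ccccc2c1OCC` gives 807 nM in this assay.

Compound 2 stands second highest of the three numbers in this assay. The nearest number is that of compound 3, and the furthest that of compound 1, yet both lie within the scatter of repeated measurements, so no order among the three can be read.

Compound 4 `CCCCCCCCn1nc2ccccc2c1OC` has not been measured. It differs from compound 2 by butyl in place of hydrogen on a saturated chain carbon, four bonds along the chain from an aromatic nitrogen. Going by the values given here, the only measured step between neighbours, a 1.1-fold lower number from compound 2 to compound 3 (0.05 log units; within the scatter), lengthens the other chain, the one on the oxygen, and moves the number hardly at all. Nothing measured here lengthens the chain on the nitrogen; compound 1 carries a shorter, branched group there, but it also differs on the oxygen side, so its number cannot be read as a chain effect on its own.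

With a chain extension on the nitrogen and no direct guide for it, the expected step of a 1.2-fold lower number from compound 2 to compound 4 (0.08 log units; within the scatter) is small and without a confident direction. Compound 4 is therefore estimated to give about 750 nM, within a range from 250 nM to 2200 nM.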

Compound 4, half-maximal inhibitory concentration: > 10000 nM
Compound 4 ended at the assay's limit; the forecaster's own chance of this, stated with the estimate: 5%; middle value at least 13-fold (1.12 log units) from the limit.
By their numbers in this assay, from the lowest: compounds 3, 2 and 1 (each within the scatter of the next). At a limit, above all of these: compound 4.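

The chain on the nitrogen turns out to matter far more than the chain on the oxygen. In this assay, going from butyl to octyl on the nitrogen gives an at least 10-fold higher number from compound 2 to compound 4 (1.04 log units; beyond the scatter), while lengthening the chain on the oxygen gave only a 1.1-fold lower number from compound 2 to compound 3 (0.05 log units; within the scatter). As far as these compounds go, for compound 4 the value > 10000 nM is a limit of the assay and not a number, so the full size of the step stays unknown: the limit of > 10000 nM in this assay, at which 1 of the 4 values shown sits. Compounds 1, 2 and 3 each lie within the scatter of the next and gave no sign of how much this position could matter, whereas this step lies beyond the scatter and shows that the length of the nitrogen chain can decide the result.

From the compounds shown here alone, with only butyl and octyl to compare on an otherwise unchanged core, it remains open whether a pentyl or hexyl chain on the nitrogen would stay close to compound 2 or already climb towards the limit. Going by these compounds, it also remains open whether a chain of octyl length ending in an amine or a carboxylic acid would behave as octyl does.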